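The compounds below may be only part of what the source reports. "The series", "measured", "known", "first", "only" and "open" are said of these compounds alone.

Measured so far in an assay on HEK293 cells for negative allosteric modulation of metabotropic glutamate receptor 5 (Homo sapiens), read by FLIPR, with a stated time of 1 h; a lower number here means a stronger inhibitor, a higher number a weaker inhibitor:
compound 1 `Fc1cccc(C#Cc2nc3c(s2)CN(C2CCC2)CC3)c1`, 200 nM
compound 2 `O=C(C1CCC1)N1CCc2nc(C#Cc3ccccc3)sc2C1`, 370 nM

Compound 1 gives the lowest of the two numbers in this assay; compound 2 sits close by, and the gap between them is within the scatter, so the two cannot be ordered. Among the measured compounds shown here, compound 2 differs from compound 1 in more than one place, so no single step between measured compounds is available.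

Compound 3 `O=C(C1CC(F)(F)C1)N1CCc2nc(C#Cc3cccc(F)c3)sc2C1` is not yet measured. It differs from compound 1 by (3,3-difluorocyclobutyl)carbonyl in place of cyclobutyl on an amine nitrogen in a ring. For the measured compounds named here, no measured pair isolates this change, and the only related comparison, compound 1 against compound 2, shows no difference beyond the scatter. With nothing in the data pointing in either direction, the step of a 1.3-fold higher number from compound 1 to compound 3 (0.11 log units; within the scatter) is expected to stay within the scatter, with a wide range to allow for the untested (3,3-difluorocyclobutyl)carbonyl group. Compound 3 is therefore estimated at 260 nM, between 70 nM and 1000 nM.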

Compound 3, half-maximal inhibitory concentration: > 10000 nM
Compound 3 was reported as a limit; the forecaster's own chance of this, stated with the estimate: 3%; middle value at least 38-fold (1.58 log units) from the limit.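

On the amine nitrogen in a ring, replacing cyclobutyl with (3,3-difluorocyclobutyl)carbonyl in this assay gives an at least 50-fold higher number from compound 1 to compound 3 (1.69 log units; beyond the scatter). Compound 3 is recorded as a limit of the assay and not as a number, so this step is a minimum: the limit of > 10000 nM in this assay, at which 1 of the 3 values shown sits. The position is therefore sensitive to this change, which compound 1 and compound 2 did not show, since their values lie within the scatter of each other.

Compound 2 differs from compound 3 in more than one place, so the carbonyl and the two fluorines of the new group cannot be assessed separately. Going by these compounds, it remains open how a 3,3-difluorocyclobutyl group placed directly on the nitrogen, or a smaller acyl group such as acetyl, would compare with compound 1.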